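The compounds below may be only part of what the source reports. "The series", "measured", "known", "first", "only" and "open" are said of these compounds alone.

Measured so far in a functional assay, read by Griess assay, with a stated time of 150 min, tested at 100 ug/mL; a lower number here means a weaker effect, a higher number a stronger effect of the compound at the concentration tested:
- compound 1 `COc1ccc(C2=NN(c3ccccc3)C(c3ccc(C)cc3)C2S(=O)(=O)CC2=NCCO2)cc1` gives 70.5%
- compound 2 `O=S(=O)(CC1=NCCS1)c1c(-c2ccc(Cl)cc2)noc1-c1ccc(Cl)cc1` is reported as "not active" (no number reported)
- compound 3 `O=S(=O)(CC1=NCCO1)c1n[nH]cc1-c1ccc(Cl)cc1` is reported as "not active" (no number reported)

Where compound 3 stands: no single number exists for it; compound 3 is reported only as "not active" (no number reported), and compound 2 is a second entry of the same kind without a number. Among the compounds with values here, compound 1 is the only entry with a number in this assay, and it shares only part of its structure with compound 3. Within the data shown here, no one-point step between measured compounds exists in this set, so no measured step size can be read off.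

Compound 4 `O=S(=O)(CC1=NCCO1)c1n[nH]cc1-c1ccccc1` differs from compound 3 by hydrogen in place of chloro on an aromatic carbon. Among the measured compounds shown here, no step between these two is computed in this assay. The expectation is for no step beyond the scatter, in either direction, because compound 3 is reported as "not active" (no number reported) and nothing in the set points to a large change from this exchange. Compound 4 is therefore expected to come out at 10%, with an estimated range from 0% to 30%, and it is likely to be reported again without a number.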

Compound 4, a percentage reported as activity, at one concentration (the size of the read-out at that concentration, not a potency): 57.5%
Compound 4: the middle estimate sits 47.5 percentage points below what was measured, and the stated range ends below it.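

In this assay compound 4 gives 57.5% and compound 3 carries only the report "not active", so no step can be read between compound 3 and compound 4. The compounds shown leave open how the 4-chlorophenyl to phenyl exchange acts on other cores. No measurement shown bears on the reason for this result.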